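A few compounds are considered here, and "the series" means these few. Any claim that something is new, unique, unknown or untested is made for them only; others in the source may bear on it.

Of the compounds shown here, two have so far been measured in an assay on isolated protein for inhibition of matrix metalloproteinase-9 (Homo sapiens), read by fluorescence, with a stated time of 30 min; on this read-out lower numbers stand for stronger inhibition and higher numbers for weaker inhibition. Compound 1 `COc1ccc(S(=O)(=O)N(CCn2cc(CCCCOc3cccnc3F)nn2)[C@@H](C(=O)NO)C(C)C)cc1` gives 0.3 nM, and compound 2 `CC(C)[C@H](C(=O)NO)N(CCn1cc(CCCF)nn1)S(=O)(=O)c1ccc(OCCF)cc1` gives 2 nM; compound 2 thus stands at the higher of the two numbers, and its distance from compound 1 lies beyond the scatter of repeated measurements. Compound 3 `CC(C)[C@H](C(=O)NO)N(CCn1cc(CCCCOc2cccnc2F)nn1)S(=O)(=O)c1ccc(OCCF)cc1` has not yet been measured in this assay. It differs from compound 2 in a single place: ((2-fluoropyridin-3-yl)oxy)methyl in place of fluoro on a saturated chain carbon, three bonds along the chain from an aromatic carbon, so that compound 3 carries the same ((2-fluoropyridin-3-yl)oxy)-bearing chain that compound 1 already has, on the shared core. Since compound 1 gives 0.3 nM with this same chain in place, compound 3 is expected to move to a lower number than compound 2, and the step of a 4.0-fold lower number from compound 2 to compound 3 (0.60 log units; beyond the scatter) is estimated to lie beyond the scatter. Compound 3 is accordingly estimated at 0.5 nM, within a range from 0.15 nM to 1.5 nM.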

Compound 3, half-maximal inhibitory concentration: 0.8 nM
Compound 3: the middle estimate sits 1.6-fold (0.20 log units) below what was measured; measured number inside the range.
By their numbers in this assay, from the lowest: compound 1; then compound 3; then compound 2.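

In this assay, ((2-fluoropyridin-3-yl)oxy)methyl in place of fluoro on the saturated chain carbon gives a 2.5-fold lower number from compound 2 to compound 3 (0.40 log units; beyond the scatter), which isolates the effect of this chain change with the rest of the molecule held fixed. With that chain held constant, fluoromethyl in place of hydrogen on a saturated chain carbon bound to an oxygen on an aromatic ring gives a 2.7-fold higher number from compound 1 to compound 3 (0.43 log units; beyond the scatter), so the gap between the two earlier compounds, which differ in both places, now divides into two modest steps that each lie beyond the scatter. No independent data explain either step.

The compounds shown leave open whether the fluorine on the pyridine ring contributes to the chain step. They also leave open how an unsubstituted phenyl ether, an amine or a carboxylic acid at the end of this chain would read.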